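This account rests on a few compounds, and the source may have more. Where it says the series, first, only, none or still open, it means among the compounds named here.

Two compounds share one core and differ only in the group carried on the phenyl ring of the piperazine side. Compound 1 `COc1ccc(N2CCN(Cn3nc(C(C)c4ccc(CC(C)C)cc4)oc3=S)CC2)cc1` carries a methoxy group there; in a functional assay on the whole organism (strain Wister albino) for inhibition, with Rattus norvegicus as the target, read by paw edema, with stated times of 30 min and 3 h, at a dose of 10 mg/kg by the oral route (on this read-out lower numbers stand for less inhibition and higher numbers for more inhibition at the one dose given (going by the name of the read-out)), compound 1 gives 42.6%. Compound 2 `CC(C)Cc1ccc(C(C)c2nn(CN3CCN(c4ccc([N+](=O)[O-])cc4)CC3)c(=S)o2)cc1` carries a nitro group at the same place, and in this assay compound 2 gives 75.1%, which is the higher of the two numbers measured. Within the data shown here, the only step measured so far is a number 32.5 percentage points higher from compound 1 to compound 2 (beyond the scatter).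

Compound 3 `CC(C)Cc1ccc(C(C)c2nn(CN3CCN(c4ccc(F)cc4)CC3)c(=S)o2)cc1` differs from compound 2 in one place: fluoro in place of nitro on an aromatic carbon. Among the measured compounds shown here, no measured step involves a fluoro group, so the single step from methoxy to nitro can only show that this position answers strongly to a change of group, not in which direction a fluoro group will pull. Compound 3 is therefore expected to land somewhere between the two measured numbers, and the step is estimated as a number 20.1 percentage points lower from compound 2 to compound 3 (beyond the scatter). For compound 3 the expected value in this assay is 55%, within a range of 35% to 75%.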

Compound 3, a percentage reported as inhibition, in the whole organism at one dose (the size of the read-out at that dose, not a potency): 75.4%
Beside the measured number, compound 3's estimate is 20.4 percentage points below it; measured number above the stated range.
By their numbers in this assay, from the lowest: compound 1; then compounds 2 and 3 (each within the scatter of the next).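

Replacing the nitro group with a fluoro group on this aromatic carbon gives a number 0.3 percentage points higher from compound 2 to compound 3 (within the scatter) in this assay, even though the nitro group counts 3 heavy atoms and 2 hydrogen-bond acceptors and the fluoro group counts 1 heavy atom and 0 hydrogen-bond acceptors. Replacing the methoxy group with a fluoro group gives a number 32.8 percentage points higher from compound 1 to compound 3 (beyond the scatter), so the large step first seen with the nitro group is not unique to that group: among these three compounds, the one carrying methoxy stands apart, while those carrying nitro and fluoro cannot be told apart. Nothing available explains why these groups read as they do.

The compounds shown leave open how this position would read with a plain hydrogen, an amine, a carboxylic acid or a longer chain such as butyl, and so whether the methoxy compound is an exception or part of a wider trend. Each number also comes from a single dose, so compound 2 and compound 3 could still separate at other doses.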